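Series notes: pyridin-3-yl in place of 4-(trifluoromethoxy)phenyl

The source may report more compounds than this note shows. Statements on the series, on what has been measured and on what is new or still open speak of the compounds shown alone.

Measured so far in a functional assay on CHO cells with adenosine receptor A1 (Homo sapiens) as the target, read by cAMP accumulation and immunoassay, with a stated time of 6 min, tested at 0.01 uM; on this read-out higher numbers stand for a weaker effect at the one concentration tested and lower numbers for a stronger effect:
- compound 1, `Nc1scc(CN2CCN(c3ccccc3C(F)(F)F)CC2)c1C(=O)c1ccc(Cl)cc1`: 0%
- compound 2, `Nc1scc(CN2CCN(c3ccc(Cl)c(C(F)(F)F)c3)CC2)c1C(=O)c1ccc(Cl)cc1`: -2.5%
- compound 3, `Nc1scc(CN2CCN(c3ccc(OC(F)(F)F)cc3)CC2)c1C(=O)c1ccc(Cl)cc1`: 0%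

Compound 3 sits level with compound 1 at the digits shown, the two together the highest of the three numbers; the remaining step is a number 2.5 percentage points higher from compound 2 to compound 3 (within the scatter), within the scatter. Compound 4, `Nc1scc(CN2CCN(c3cccnc3)CC2)c1C(=O)c1ccc(Cl)cc1`, is unmeasured; it differs from compound 3 by pyridin-3-yl in place of 4-(trifluoromethoxy)phenyl on an amine nitrogen in a ring.

For the measured compounds named here, the steps that bear on this place are no change at the digits printed from compound 1 to compound 3 (within the scatter) and a number 2.5 percentage points lower from compound 1 to compound 2 (within the scatter), both within the scatter: three different aryl groups on the ring nitrogen all gave no measurable effect. Nothing here separates the aryl groups, so the change to pyridin-3-yl is expected to give no step beyond the scatter, no change at the digits printed from compound 3 to compound 4 (within the scatter). Compound 4 is therefore estimated at 0%, between -10% and 10%.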

Compound 4, a percentage reported as activity, at one concentration (the size of the read-out at that concentration, not a potency): 3.2%
Estimate against measurement, compound 4: 3.2 percentage points below; the range from low to high includes it.
By their numbers in this assay, from the lowest: compounds 2, 1, 3 and 4 (each within the scatter of the next).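

Pyridin-3-yl places a ring hetero atom on the ring nitrogen's aryl group for the first time in the series, yet in this assay the steps remain small: a number 3.2 percentage points higher from compound 3 to compound 4 (within the scatter), a number 5.7 percentage points higher from compound 2 to compound 4 (within the scatter) and a number 3.2 percentage points higher from compound 1 to compound 4 (within the scatter). Among these four compounds, removing the halogen-bearing substituents from this aryl group therefore does not separate compound 4 from the others. No supporting measurement bears on this result.

On these data alone, whether any group at this place can move the read-out beyond the scatter remains open. A cyclohexyl group, a benzyl group or an aryl ring carrying a carboxylic acid could test that.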